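Solubility of an acetoxymethyl analogue: an expectation

The source may report more compounds than this note shows. Statements on the series, on what has been measured and on what is new or still open speak of the compounds shown alone.

Compound 1 `CN(CCC#N)C[C@H]1CN(c2ccc(-n3cc(-c4ccccn4)cn3)c(F)c2)C(=O)O1` gives 64500 nM in a physicochemical assay for solubility, read by HPLC, with a stated time of 24 h; on this read-out lower numbers stand for lower solubility and higher numbers for higher solubility.
Compound 2 `COC(=O)CC1CCN(C[C@H]2CN(c3ccc(-n4cc(-c5ccccn5)cn4)c(F)c3)C(=O)O2)CC1` gives 92100 nM in this assay.
Compound 3 `O=C1O[C@@H](CN2CCC(c3ccc(F)cc3)CC2)CN1c1ccc(-n2cc(-c3ccccn3)cn2)c(F)c1` gives, in this assay, a limit of the assay, <= 19400 nM.

Of the two numbers measured, compound 2 and compound 1 lie within the scatter of each other, since a 1.4-fold higher number from compound 1 to compound 2 (0.15 log units; within the scatter); the third result, that of compound 3, is a limit rather than a number. Compound 4 `CC(=O)OC[C@H]1CN(c2ccc(-n3cc(-c4ccccn4)cn3)c(F)c2)C(=O)O1` differs from compound 2 by acetoxy in place of 4-((methoxycarbonyl)methyl)piperidin-1-yl on a saturated chain carbon bound to a saturated ring carbon. Going by the values given here, no measured step reproduces this change. The step of a 1.4-fold higher number from compound 1 to compound 2 (0.15 log units; within the scatter) swapped the group on the same saturated chain carbon and stayed within the scatter, while an at least 4.7-fold lower number from compound 2 to compound 3 (0.67 log units; beyond the scatter) changed a group on the six-membered ring and went beyond it. The change to compound 4 removes the whole six-membered ring and its ester rather than exchanging a group on it, so the two measured steps give only loose guidance. A lowering of the number in this assay beyond the scatter is expected for compound 4, though a result near compound 2 cannot be excluded, and the step is estimated as a 3.1-fold lower number from compound 2 to compound 4 (0.49 log units; beyond the scatter). Compound 4 is therefore expected to give 30000 nM in this assay, with a range from 8000 nM to 90000 nM.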

Compound 4, solubility: 373000 nM
For compound 4 the middle estimate is 12-fold (1.09 log units) below the measured one; the whole stated range lies below it.
By their numbers in this assay, from the lowest: compounds 1 and 2 (each within the scatter of the next); then compound 4. At a limit, below all of these: compound 3.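

In this assay, the place on a saturated chain carbon bound to a saturated ring carbon now proves able to move the number, with acetoxy giving a 4.0-fold higher number from compound 2 to compound 4 (0.61 log units; beyond the scatter) and a 5.8-fold higher number from compound 1 to compound 4 (0.76 log units; beyond the scatter), whereas the earlier exchange at this place, a 1.4-fold higher number from compound 1 to compound 2 (0.15 log units; within the scatter), had stayed within the scatter. The rise appears whether the group that leaves is 4-((methoxycarbonyl)methyl)piperidin-1-yl, with its six-membered ring, or (2-cyanoethyl)(methyl)amino, which has no ring, so it is not tied to the loss of that ring alone. Nothing measured here explains the rise, and the one available observation, a limit on a different compound, does not bear on it.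

The compounds shown leave open whether the acetoxy group itself matters or whether any small group without a ring nitrogen or amino nitrogen at this place would give a similar number. A hydroxyl, a primary amine or a carboxylic acid on this same chain carbon could separate these readings, as could a longer ester such as propionyloxy.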